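This account rests on a few compounds, and the source may have more. Where it says the series, first, only, none or still open, it means among the compounds named here.

Compound 1 `CCc1ccc(NC2=CC(=O)c3c(nc4n3[C@H]3OC[C@@H](O)[C@H]3OC4)C2=O)cc1` carries a 4-ethylphenyl group on the amine nitrogen of the shared core. In a functional assay on ECa-109 cells for inhibition, with ECa-109 cell line (Homo sapiens) as the target, read by sulforhodamine B assay (a higher number here means a weaker inhibitor, a lower number a stronger inhibitor), compound 1 gives > 4000 nM, which is a limit of the assay rather than a number, so compound 1 stands only at the weak end of the three values shown. Compound 3 `Cc1ccc(NC2=CC(=O)c3nc4n(c3C2=O)[C@H]2OC[C@@H](O)[C@H]2OC4)cc1`, which bears a 4-methylphenyl group in the same place, gives 3480 nM in this assay. Compound 2 `O=C1C=C(NC2CCCC2)C(=O)c2c1nc1n2[C@H]2OC[C@@H](O)[C@H]2OC1`, with a cyclopentyl group, gives > 16000 nM in this assay, again a limit. Among the measured compounds shown here, the one measured step, an at least 4.5-fold lower number from compound 2 to compound 3 (0.66 log units; beyond the scatter), concerns a change of ring type on the nitrogen and does not touch the chain on the aryl ring.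

Compound 4 `CCCc1ccc(NC2=CC(=O)c3c(nc4n3[C@H]3OC[C@@H](O)[C@H]3OC4)C2=O)cc1` differs from compound 1 by methyl in place of hydrogen on a saturated chain carbon, two bonds along the chain from an aromatic carbon. For the measured compounds named here, no measured step bears on this kind of change, and the values of compound 1 and compound 3 give no sign that lengthening this chain moves the number. Compound 4 is therefore expected to show no step beyond the scatter, a step that the limit leaves unreadable from compound 1 to compound 4, and its value is estimated at 6000 nM, within 2500 nM to 20000 nM, quite possibly again only a limit.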

Compound 4, half-maximal inhibitory concentration: > 4000 nM
Compound 4 gave a limit, no number; the forecaster's own chance of this, stated with the estimate: 60%; the middle value does not contradict the limit.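

Among the compounds shown here, compound 1 and compound 4 both end at a limit of the assay rather than at a number, so no step between them can be read: the limit of > 4000 nM in this assay, at which 2 of the 4 values shown sit. The compounds shown leave open whether 4-propylphenyl in place of 4-ethylphenyl moves the number at all in this assay.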